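Working notes: a chloro added to compound 2

The compounds below may be only part of what the source reports. "The series", "measured", "known", "first", "only" and "open" are said of these compounds alone.

Compound 1 `COc1ccc(-c2ccnc(Nc3ccc(Cl)cc3)n2)cc1` and compound 2 `Clc1ccc(Nc2nccc(-c3ccc(Br)cc3)n2)cc1` share one core and differ in a single place. In an assay on isolated protein for inhibition of phosphatidylinositol 4,5-bisphosphate 3-kinase catalytic subunit beta isoform (Homo sapiens) (on this read-out higher numbers stand for weaker inhibition and lower numbers for stronger inhibition), compound 1 gives 603 nM, and compound 2 gives 946 nM. Within the data shown here, the only measured step, a 1.6-fold higher number from compound 1 to compound 2 (0.20 log units; within the scatter), does not exceed the scatter, so compound 2 stands at the higher of the two numbers in this assay only nominally, with compound 1 its sole neighbour. Compound 3 `Clc1ccc(Nc2nccc(-c3ccc(Br)cc3)n2)c(Cl)c1` is not yet measured; it differs from compound 2 by chloro in place of hydrogen on an aromatic carbon. Among the measured compounds shown here, no measured step touches that position: the one available step, a 1.6-fold higher number from compound 1 to compound 2 (0.20 log units; within the scatter), exchanged a group on an aromatic carbon elsewhere in the molecule and stayed within the scatter. There is thus no ground for expecting a move in either direction, and the step from compound 2 to compound 3 in this assay is expected to be about a 1.1-fold lower number from compound 2 to compound 3 (0.02 log units; within the scatter), within the scatter. Compound 3 is accordingly estimated at 900 nM, in a range from 300 nM to 3000 nM.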

Compound 3, half-maximal inhibitory concentration: 673 nM
Estimate against measurement, compound 3: 1.3-fold (0.13 log units) above; measured number inside the range.
By their numbers in this assay, from the lowest: compounds 1, 3 and 2 (each within the scatter of the next).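

Chloro in place of hydrogen on an aromatic carbon, ortho to a large group and meta to a chloro group, is the first change at this position, and in this assay it gives a step that stays within the scatter (a 1.4-fold lower number from compound 2 to compound 3 (0.15 log units; within the scatter)). The earlier step (a 1.6-fold higher number from compound 1 to compound 2 (0.20 log units; within the scatter)) lay elsewhere in the molecule and said nothing about this carbon; the new one shows that this position takes an added chloro without a shift that can be told from the scatter. No measurement beyond these numbers speaks to the reason for this result.

On these data alone, whether an amine or a carboxylic acid on this same carbon would also stay within the scatter of compound 2 remains open. Also open, as far as these compounds go, is whether the added chloro gives a similar step with methoxy in place of bromo, as in compound 1.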